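Thiazolyl for pyrimidinyl on the phenoxymethyl-imidazoline core

A few compounds are considered here, and "the series" means these few. Any claim that something is new, unique, unknown or untested is made for them only; others in the source may bear on it.

Measured so far:
compound 1, `c1cnc(-c2ccccc2OCC2=NCCN2)nc1`, 1260 nM
compound 2, `c1ccc(-c2ccncn2)c(OCC2=NCCN2)c1`, < 100000 nM

For the measured compounds named here, compound 1 is the only compound here with a definite number in a functional assay for activation of Alpha-1A adrenergic receptor (Homo sapiens), read by calcium flux; a lower number here means that less compound is needed, a higher number that more compound is needed for the effect. For compound 2 this assay gives only a limit, < 100000 nM, and not a number. Going by the values given here, the one measured step, a step that the limit leaves unreadable from compound 1 to compound 2, is therefore unreadable in size, as the limit of < 100000 nM in this assay, at which 1 of the 2 values shown sits, shows.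

Compound 3, `Cc1csc(-c2ccccc2OCC2=NCCN2)n1`, is formed from compound 2 by the change (4-methyl-1,3-thiazol-2-yl in place of pyrimidin-4-yl on an aromatic carbon). Among the compounds with values here, no measured step bears on this change: the only step known involves a ring exchange on the same carbon, and its size cannot be read from a limit. Compound 2 itself stands only as a limit, so the starting point of the step is not a number either.

The size of a step that the limit leaves unreadable from compound 2 to compound 3 is an estimate made without a readable reference step. Compound 3 is expected to give about 4000 nM, with a range from 400 nM to 40000 nM.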

Compound 3, half-maximal effective concentration: 25.1 nM
Compound 3: the middle estimate sits 160-fold (2.20 log units) above what was measured, outside the stated range (below it).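

In this assay, for the compounds shown here, the change to 4-methyl-1,3-thiazol-2-yl in place of pyrimidin-2-yl gives a 50-fold lower number from compound 1 to compound 3 (1.70 log units; beyond the scatter), the first readable step at this aromatic carbon. It shows that the position is not limited to six-membered aromatic rings and that a five-membered aromatic ring carrying sulfur and a methyl group can go with much less compound needed for the effect. The steps that involve compound 2 cannot be read: the limit of < 100000 nM in this assay, at which 1 of the 3 values shown sits.

The compounds shown leave open how much of the readable step belongs to the methyl group and how much to the ring itself, which the plain 1,3-thiazol-2-yl group would separate. Also open, as far as these compounds go, is how an ethyl group, a methoxy group or an amine would fare in place of that methyl on the thiazole.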